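The compounds below may be only part of what the source reports. "The series", "measured", "known", "first", "only" and "open" are said of these compounds alone.

In an assay on HEK-293T cells for antagonist activity at vitamin D3 receptor (Homo sapiens), read by a luciferase reporter, with a stated time of 24 h (on this read-out higher numbers stand for weaker inhibition and lower numbers for stronger inhibition), compound 1 `CC(C)c1onc(-c2c(Cl)cccc2Cl)c1COc1ccc(-c2nc3ccc(C(=O)O)cc3n2CC(C)(C)C)cc1` gives 861 nM.
Compound 2 `CCCC(CCC)n1c(-c2ccc(OCc3c(-c4c(Cl)cccc4Cl)noc3C(C)C)cc2)nc2ccc(C(=O)O)cc21` gives > 10000 nM, which is a limit of this assay.
Compound 3 `CC(C)c1onc(-c2c(Cl)cccc2Cl)c1COc1ccc(-c2nc3ccc(C(=O)O)cc3n2-c2ccc(F)cc2)cc1` gives 2410 nM.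

Compound 3 thus holds the highest of the two numbers, its nearest neighbour being compound 1 with a 2.8-fold higher number from compound 1 to compound 3 (0.45 log units; beyond the scatter); compound 2 sits at the limit of > 10000 nM in this assay, at which 1 of the 3 values shown sits. Compound 4 `CC(C)c1onc(-c2c(Cl)cccc2Cl)c1COc1ccc(-c2nc3ccc(C(=O)O)cc3n2CC2CCCCC2)cc1` differs from compound 3 by cyclohexylmethyl in place of 4-fluorophenyl on an aromatic nitrogen. For the measured compounds named here, the steps that bear on it are an at least 11-fold higher number from compound 1 to compound 2 (1.06 log units; beyond the scatter), a 2.8-fold higher number from compound 1 to compound 3 (0.45 log units; beyond the scatter) and an at least 4.1-fold lower number from compound 2 to compound 3 (0.61 log units; beyond the scatter): a branched alkyl attached through one carbon gave the lowest number, a branched alkyl attached at a branching carbon the limit, and the aryl a number in between. Cyclohexylmethyl resembles neopentyl in its attachment, so compound 4 is expected to show a modest lowering, a 1.7-fold lower number from compound 3 to compound 4 (0.24 log units; within the scatter), with an estimated 1400 nM (range 450 nM to 5500 nM).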

Compound 4, half-maximal inhibitory concentration: 346 nM
Compound 4: middle estimate off by 4.0-fold (0.61 log units), on the high side; the whole stated range lies above it.
By their numbers in this assay, from the lowest: compound 4; then compound 1; then compound 3. At a limit, above all of these: compound 2.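

With the heavy-atom count unchanged, cyclohexylmethyl on the aromatic nitrogen gives a clearly lower number than 4-fluorophenyl (a 7.0-fold lower number from compound 3 to compound 4 (0.84 log units; beyond the scatter)), so that count alone does not set the value at this position. Among the groups attached through one carbon, cyclohexyl in place of tert-butyl also lowers the number (a 2.5-fold lower number from compound 1 to compound 4 (0.40 log units; beyond the scatter)). The widest step (an at least 28-fold lower number from compound 2 to compound 4 (1.46 log units; beyond the scatter)) is bounded only, as compound 2 stands at a limit: the limit of > 10000 nM in this assay, at which 1 of the 4 values shown sits.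

Compound 3 and compound 4 differ in both the ring and the linking carbon, so a benzyl group would be needed to separate the two. On these data alone, whether cyclopentylmethyl or a tetrahydropyranylmethyl group would fit this position as well remains open.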